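This account rests on a few compounds, and the source may have more. Where it says the series, first, only, none or still open, it means among the compounds named here.

Three compounds have been measured in a functional assay (aorta) with Oryctolagus cuniculus as the target; a higher number here means a weaker inhibitor, a lower number a stronger inhibitor:

Compound 1 `CC1=NC(C)=C(C(=O)OCCCN2C(=O)c3ccccc3S2(=O)=O)C(c2ccccc2[N+](=O)[O-])/C1=C(\O)OCC1CCCO1` gives 6.8 nM
Compound 2 `CC1=NC(C)=C(C(=O)OCCCN2C(=O)c3ccccc3S2(=O)=O)C(c2ccccc2[N+](=O)[O-])/C1=C(\O)OCC1CCCCO1` gives 11.5 nM
Compound 3 `CC1=NC(C)=C(C(=O)OCCCN2C(=O)c3ccccc3S2(=O)=O)C(c2ccccc2Cl)/C1=C(\O)OCC1CCCO1` gives 7.1 nM

Compound 1 and compound 2 share one core and differ in a single place: oxan-2-yl in place of oxolan-2-yl on a saturated chain carbon bound to an oxygen on an unsaturated carbon. This change produced a 1.7-fold higher number from compound 1 to compound 2 (0.23 log units; within the scatter). The core of compound 3 differs from that of compound 1 in one place as well: chloro in place of nitro on an aromatic carbon. That change produced a 1.0-fold higher number from compound 1 to compound 3 (0.02 log units; within the scatter), so the two cores behave alike in this assay.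

Compound 4 `CC1=NC(C)=C(C(=O)OCCCN2C(=O)c3ccccc3S2(=O)=O)C(c2ccccc2Cl)/C1=C(\O)OCC1CCCCO1` has not yet been measured. It stands to compound 3 as compound 2 stands to compound 1: oxan-2-yl in place of oxolan-2-yl on a saturated chain carbon bound to an oxygen on an unsaturated carbon. The place of the change is described in the same words in both pairs, so it is the same change, made here on the core of compound 3 rather than on the core of compound 1.

The account expects the step from compound 3 to compound 4 to be a 1.7-fold higher number from compound 3 to compound 4 (0.23 log units; within the scatter), a size much like the earlier one, since the same change gave a 1.7-fold higher number from compound 1 to compound 2 (0.23 log units; within the scatter) and the two cores gave almost the same number in this assay. On that basis compound 4 is estimated at 12 nM, with a likely range from 5 nM to 28 nM.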

Compound 4, half-maximal inhibitory concentration: 7 nM
Compound 4: the middle estimate sits 1.7-fold (0.23 log units) above what was measured; the measured number falls inside the stated range.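

In this assay, putting oxan-2-yl in place of oxolan-2-yl on the core of compound 3 gave a 1.0-fold lower number from compound 3 to compound 4 (0.01 log units; within the scatter), and this step does not differ from the one seen for the same change on the core of compound 1: the same change on two cores in this assay, a 1.7-fold higher number (0.23 log units; within the scatter) from compound 1 to compound 2 and a 1.0-fold lower number (0.01 log units; within the scatter) from compound 3 to compound 4, 1.7-fold (0.23 log units) apart, within the scatter of two such steps. Chloro in place of nitro on an aromatic carbon, read on the compounds that carry oxan-2-yl, gave a 1.6-fold lower number from compound 2 to compound 4 (0.22 log units; within the scatter), and this step also agrees with its earlier counterpart: the same change on two cores in this assay, a 1.0-fold higher number (0.02 log units; within the scatter) from compound 1 to compound 3 and a 1.6-fold lower number (0.22 log units; within the scatter) from compound 2 to compound 4, 1.7-fold (0.23 log units) apart, within the scatter of two such steps. Among these four compounds, then, the change carries from one core to the other with no difference that can be told from the scatter, but every step is itself within the scatter, so the data do not show that either change has a real effect on either core, or that a larger effect would carry over in the same way.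

What the compounds shown leave open is whether the same agreement would hold with a methoxy or trifluoromethyl group in place of chloro or nitro on the aromatic carbon. From the compounds shown here alone, it is also open what a longer open chain or an amine would do in place of oxolan-2-yl or oxan-2-yl on the saturated chain carbon.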